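Replacing 1H-indol-2-yl with 4-methoxyphenyl

A few compounds are considered here, and "the series" means these few. Any claim that something is new, unique, unknown or untested is made for them only; others in the source may bear on it.

In a functional assay on MCF7 cells (Homo sapiens) for antiproliferative activity (on this read-out lower numbers stand for an effect already at smaller amounts and higher numbers for an effect only at larger amounts of compound), compound 3 `CCOC(=O)C(=O)Nc1ccc2nc(NC(=O)c3cc4ccccc4[nH]3)sc2c1` gives 8990 nM, and compound 1 `CCOC(=O)C(=O)Nc1ccc2nc(NC(=O)c3cc4cc(C)ccc4[nH]3)sc2c1` gives 10100 nM. Those two values belong together, as the measured step shows: a 1.1-fold lower number from compound 1 to compound 3 (0.05 log units; within the scatter). Compound 2 `CCOC(=O)C(=O)Nc1ccc2nc(NC(=O)c3ncccn3)sc2c1` reached only a limit of this assay, > 50000 nM.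

Compound 4 `CCOC(=O)C(=O)Nc1ccc2nc(NC(=O)c3ccc(OC)cc3)sc2c1` keeps the shared core of compound 3 and changes one group: 4-methoxyphenyl in place of 1H-indol-2-yl on a carbonyl carbon. The best guide is the earlier exchange at that same carbonyl carbon, which brought in pyrimidin-2-yl. Two steps record it: an at least 4.9-fold higher number from compound 1 to compound 2 (0.69 log units; beyond the scatter), and an at least 5.5-fold lower number from compound 2 to compound 3 (0.74 log units; beyond the scatter). Going by the values given here, both show that the group at this place matters, and that the one compound lacking an indolyl group gave the higher number. That is a single example with a different group, so it guides the direction more firmly than the size.

The estimated step in this assay is a 2.4-fold higher number from compound 3 to compound 4 (0.39 log units; beyond the scatter), towards a higher number. For compound 4 the expected value is 22000 nM, with an estimated range of 7000 nM to 50000 nM.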

Compound 4, half-maximal effective concentration: > 50000 nM
Compound 4: no number, only a limit; the forecaster's own chance of this, stated with the estimate: 35%; middle value at least 2.2-fold (0.35 log units) away from the limit.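

In this assay, 4-methoxyphenyl on the carbonyl carbon gives an at least 5.5-fold higher number from compound 3 to compound 4 (0.74 log units; beyond the scatter) and an at least 4.9-fold higher number from compound 1 to compound 4 (0.69 log units; beyond the scatter). The earlier loss therefore does not belong to pyrimidin-2-yl alone: a six-membered aromatic ring of carbon only, with no hydrogen-bond donor, also ends at the top of the measurable range, so neither compound without an indolyl group gives a number here. The step between the two compounds without an indolyl group cannot be read, because both values are limits and not numbers: the limit of > 50000 nM in this assay, at which 2 of the 4 values shown sit.

The change to 4-methoxyphenyl removes the five-membered ring and the hydrogen-bond donor together, so the compounds shown cannot tell which of the two matters. Going by these compounds, a 1H-pyrrol-2-yl group would keep the nitrogen-hydrogen without the six-membered ring, and a benzofuran-2-yl group would keep two fused rings with oxygen in place of that nitrogen-hydrogen; how either behaves here stays open.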